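The source may report more compounds than this note shows. Statements on the series, on what has been measured and on what is new or still open speak of the compounds shown alone.

Measured compounds:
compound 1, `Cc1nc(S(C)(=O)=O)ccc1Oc1ncnc(OC2CCN(C(=O)OC(C)(C)C#N)CC2)c1F`, 92.9 nM
compound 2, `CCC1(OC(=O)N2CCC(Oc3ncnc(Oc4ccc(S(C)(=O)=O)nc4C)c3F)CC2)CC1`, 22 nM
compound 3, `Cc1nc(S(C)(=O)=O)ccc1Oc1ncnc(OC2CCN(C(=O)SC3CC3)CC2)c1F`, 24.9 nM

These three compounds were tested in a functional assay on isolated protein for inhibition of Glucose-dependent insulinotropic receptor (Homo sapiens), read by HTRF and cAMP accumulation; on this read-out lower numbers stand for an effect already at smaller amounts and higher numbers for an effect only at larger amounts of compound. Compound 1 gives the highest of the three numbers in this assay; compound 3 comes nearest, and compound 2 lies furthest away, both beyond the scatter. The unmeasured compound 4, `Cc1nc(S(C)(=O)=O)ccc1Oc1ncnc(OC2CCN(C(=O)C(C)(F)F)CC2)c1F`, is built from compound 1 by one change: 1,1-difluoroethyl in place of 1-cyano-1-methylethoxy on a carbonyl carbon. Both measured steps that start from compound 1 swap out the same 1-cyano-1-methylethoxy group on that carbonyl carbon. The step of a 4.2-fold lower number from compound 1 to compound 2 (0.63 log units; beyond the scatter) and the step of a 3.7-fold lower number from compound 1 to compound 3 (0.57 log units; beyond the scatter) lowered the number by a similar, modest amount. The third step, a 1.1-fold higher number from compound 2 to compound 3 (0.05 log units; within the scatter), lay within the scatter, so among these compounds the exact shape of the entering group mattered less than leaving the original group behind. Because compound 4 also loses the group whose replacement gave a 3.7-fold lower number from compound 1 to compound 3 (0.57 log units; beyond the scatter), a modest lowering is expected in this assay, about a 2.7-fold lower number from compound 1 to compound 4 (0.42 log units; beyond the scatter). Compound 4 is therefore estimated at 35 nM, with a plausible range from 12 nM to 110 nM. Going by the values given here, no measured compound carries a 1,1-difluoroethyl group, so the range is kept wide.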

Compound 4, half-maximal effective concentration: 37 nM
Estimate against measurement, compound 4: 1.1-fold (0.02 log units) below; the range from low to high includes it.
By their numbers in this assay, from the lowest: compounds 2, 3 and 4 (each within the scatter of the next); then compound 1.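

The step, a 2.5-fold lower number from compound 1 to compound 4 (0.40 log units; beyond the scatter), shows in this assay that the number also falls when the entering group has no ring, no oxygen and no sulfur, and is joined to the carbonyl carbon through its own carbon. Compared with the two ring-bearing groups, the changes a 1.5-fold higher number from compound 3 to compound 4 (0.17 log units; within the scatter) and a 1.7-fold higher number from compound 2 to compound 4 (0.23 log units; within the scatter) both lie within the scatter, so compounds 2, 3 and 4 cannot be told apart here, and among these four compounds only compound 1, with its 1-cyano-1-methylethoxy group, stands apart from the others. Nothing shown here gives a measured reason for this behaviour.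

As far as these compounds go, what a plain ethyl group on the same carbonyl carbon would give, and so whether the two fluorines matter at all, remains open. Also open, from the compounds shown here alone, is whether the nitrile alone sets compound 1 apart, and how an amine or a carboxylic acid in this place would read.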